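Amino-thiazole acylguanidines: propyl replaces 1-phenylethyl

A few compounds are considered here, and "the series" means these few. Any claim that something is new, unique, unknown or untested is made for them only; others in the source may bear on it.

Measured compounds:
- compound 1, `N/C(=N\C(=O)NC1CCCCC1)Nc1cccc(-c2csc(N)n2)c1`: 4470 nM
- compound 2, `N/C(=N\C(=O)NCc1ccccc1)NC1CCc2nc(N)sc2C1`: 513 nM
- compound 3, `Cc1nc(N)sc1CCCN/C(N)=N/C(=O)N[C@@H](C)c1ccccc1`: 51.3 nM

All three numbers come from an assay on membranes from Sf9 cells for displacement of a labelled ligand from histamine H2 receptor (Homo sapiens), read by scintillation counting, with a stated time of 60 min; on this read-out lower numbers stand for stronger inhibition and higher numbers for weaker inhibition. Among them compound 3 gives the lowest inhibition constant; compound 2 sits nearest, and its step up from compound 3 lies beyond the scatter, while compound 1 lies furthest, also beyond the scatter. Compound 3 is therefore the strongest binder of the three in this assay.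

The next compound keeps the core of compound 3 and changes only the substituent on the amide-type nitrogen: compound 4, `CCCNC(=O)/N=C(\N)NCCCc1sc(N)nc1C`. The difference counted from the two structures is propyl in place of 1-phenylethyl on an amide-type nitrogen. Going by the values given here, no measured pair in the set isolates this exchange on the shared core; compound 2, which carries a ring-bearing group in that place on another core, shows a higher inhibition constant than compound 3 but does not tell what removal of the ring itself does.

Given the loss of the aromatic ring, the inhibition constant of compound 4 is expected to rise; the step of a 3.9-fold higher number from compound 3 to compound 4 (0.59 log units; beyond the scatter) is estimated to exceed the scatter. For compound 4 the estimate in this assay is 200 nM, within a range from 60 nM to 700 nM.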

Compound 4, inhibition constant: 105 nM
Estimate against measurement, compound 4: 1.9-fold (0.28 log units) above; the range from low to high includes it.
By their numbers in this assay, from the lowest: compound 3; then compound 4; then compound 2; then compound 1.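

In this assay, propyl in place of 1-phenylethyl on the amide-type nitrogen gives a 2.0-fold higher number from compound 3 to compound 4 (0.31 log units; beyond the scatter), a modest step on the shared core, though one beyond the scatter. Compound 4, with no ring at this position, still gives 105 nM, so the six-membered aromatic ring is not required for binding at this level on this core. Nothing available gives a reason for the step.

The ring and the defined stereocentre leave together in this single exchange, so their separate contributions to the step remain unresolved. On the shared core, an unbranched 2-phenylethyl group would test the ring without the stereocentre, and a longer chain such as hexyl would show whether chain length alone can close the gap to compound 3.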